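Swapping the amide aryl group: an untested direction

The source may report more compounds than this note shows. Statements on the series, on what has been measured and on what is new or still open speak of the compounds shown alone.

Two compounds share a core, differing only at the far end of the chain. Compound 1 `CC(C)COc1ccc(NC(=O)CCCCCCCSc2nnc(Cc3nn(C)c(=O)c4ccccc34)n2C)cc1` and compound 2 `CCCOc1ccc(NC(=O)CCCCCCCSc2nnc(Cc3nn(C)c(=O)c4ccccc34)n2C)cc1` were both measured in an assay on isolated protein for binding affinity to interleukin-15 (Homo sapiens), read by surface plasmon resonance; on this read-out higher numbers stand for weaker binding and lower numbers for tighter binding. In this assay compound 1 gives 25000 nM, and compound 2 gives 19000 nM. The step of a 1.3-fold lower number from compound 1 to compound 2 (0.12 log units; within the scatter) is within the scatter, so the two numbers cannot be told apart, and compound 2 stands alongside compound 1 rather than ahead of it.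

Compound 3 `Cn1c(Cc2nn(C)c(=O)c3ccccc23)nnc1SCCCCCCCC(=O)Nc1ccc(Cl)cc1Cl` has not yet been measured. It differs from compound 2 by 2,4-dichlorophenyl in place of 4-propoxyphenyl on an amide-type nitrogen. Going by the values given here, the only measured step, from compound 1 to compound 2, touches a saturated chain carbon on the propoxy side and says nothing about replacing the whole 4-propoxyphenyl group with a 2,4-dichlorophenyl group. Among the compounds with values here, no measured step therefore bears on this change, and there is no basis for expecting a shift in either direction beyond the scatter.

Compound 3 is accordingly estimated at 20000 nM, within a range of 5000 nM to 80000 nM, which is an expected step of a 1.1-fold higher number from compound 2 to compound 3 (0.02 log units; within the scatter) from compound 2.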

Compound 3, dissociation constant: 19100 nM
Compound 3: the middle estimate sits 1.0-fold (0.02 log units) above what was measured, and the stated range covers the measured number.
By their numbers in this assay, from the lowest: compounds 2, 3 and 1 (each within the scatter of the next).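

Going by these compounds alone, until now the only comparison was a small trim of the alkoxy chain, but here the whole aryl group on the amide-type nitrogen changes, and this assay shows no readable difference, with a 1.0-fold higher number from compound 2 to compound 3 (0.00 log units; within the scatter). The swap is a large one on paper: 4-propoxyphenyl, with 10 heavy atoms and 1 hydrogen-bond acceptor, gives way to 2,4-dichlorophenyl, with 8 heavy atoms and 0 hydrogen-bond acceptors, yet the number stays within the scatter. The comparison with the branched ether points the same way, with a 1.3-fold lower number from compound 1 to compound 3 (0.12 log units; within the scatter), so all three compounds sit within the scatter of one another, and no measurement is available to explain why these different aryl groups read alike.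

The three compounds leave open whether any group on this nitrogen can move the number beyond the scatter, for example a phenyl ring carrying an amine or a carboxylic acid. They also leave open whether a longer chain in place of the shared one would matter more than the aryl group does.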